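This account rests on a few compounds, and the source may have more. Where it says the series, first, only, none or still open, it means among the compounds named here.

Compound 1 `COc1cccc(C2SCC(=O)N2c2nnc(CNn3c(C)nc4ccc(Br)cc4c3=O)s2)c1`: 60%
Compound 2 `COc1cccc(C2SCC(=O)N2c2nnc(CNn3c(C)nc4ccccc4c3=O)s2)c1`: 60%
Compound 3 `Cc1nc2ccccc2c(=O)n1NCc1nnc(/N=C/c2ccc(O)cc2)s1`: 50%

The three compounds were tested in a functional assay on the whole organism (strain albino) with Rattus norvegicus as the target, in the maximal electroshock model, with a stated time of 1 h, at a dose of 30 mg/kg by the intraperitoneal route; a lower number here means less inhibition, a higher number more inhibition at the dose given (going by the name of the read-out). In this assay compound 2 gives 60%, and compound 1 gives 60%, the same number at the digits printed. Compound 3 gives 50%, a value that lies within the usual scatter of the other two, so nothing in these three numbers sets any of them apart.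

Compound 4 `COc1ccc(C2SCC(=O)N2c2nnc(CNn3c(C)nc4ccccc4c3=O)s2)cc1` has not yet been measured. It differs from compound 2 in a single place: 4-methoxyphenyl in place of 3-methoxyphenyl on a saturated ring carbon. The shared core, the rest of the molecule, stays as it is.

Among the compounds with values here, only one measured step exists, and it concerns a different part of the molecule: no change at the digits printed from compound 1 to compound 2 (within the scatter). Within the data shown here, that step tells nothing directly about moving the methoxy group around its ring, and no measured pair here does. With no evidence of a change from this kind of move, the expected step from compound 2 to compound 4 is no change at the digits printed from compound 2 to compound 4 (within the scatter), that is, none beyond the scatter. Compound 4 is therefore estimated at 60%, with a range from 45% to 70%.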

Compound 4, a percentage reported as inhibition, in the whole organism at one dose (the size of the read-out at that dose, not a potency): 60%
Estimate against measurement, compound 4: no gap at the digits printed; low and high end bracket the measured number.
By their numbers in this assay, from the lowest: compounds 3, 1, 2 and 4 (each within the scatter of the next).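

In this assay, within the data shown here, replacing 3-methoxyphenyl with 4-methoxyphenyl on a saturated ring carbon gives no change at the digits printed from compound 2 to compound 4 (within the scatter), the first reading of any change at this place on the molecule. The earlier step, no change at the digits printed from compound 1 to compound 2 (within the scatter), concerned a bromo on an aromatic carbon elsewhere, so it said nothing about this ring carbon; the new pair shows that, at this one dose, both methoxyphenyl groups are compatible with a read-out at the level of the other compounds in this series. The two compounds have the same atoms and the same counts of hydrogen-bond donors and acceptors in the changed group, and no measurement is available to explain why their results match.

As far as these compounds go, whether a different group on this phenyl ring, such as an amine or a carboxylic acid, would stay within the scatter of compound 2 at 60% remains open. Also open, from the compounds shown here alone, is whether compound 2 and compound 4 would still match at other doses or times, since a single-dose percentage reports the size of the effect and not a potency.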